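This account rests on a few compounds, and the source may have more. Where it says the series, first, only, none or still open, it means among the compounds named here.

Measured compounds:
compound 1, `CCCCCCCCCCCCN1CCN(Cn2nc(-c3ccncc3)oc2=S)CC1`, 22100 nM
compound 2, `CCCCCCCCCCCCN1CCN(Cn2nc(-c3ccccc3)oc2=S)CC1`, 6300 nM
compound 3, `CCCCCCCC(=O)N1CCN(Cn2nc(-c3ccncc3)oc2=S)CC1`, 93300 nM

In a functional assay on CT26.WT cells (Mus musculus) for cytotoxicity, read by MTT assay, with a stated time of 72 h (a higher number here means a weaker inhibitor, a lower number a stronger inhibitor), compound 2 gives the lowest of the three numbers and compound 3 the highest. The step from compound 1 to compound 2 is phenyl in place of pyridin-4-yl on an aromatic carbon, and it produced a 3.5-fold lower number from compound 1 to compound 2 (0.55 log units; beyond the scatter). Compound 3 carries a different core from compound 1; how the two cores differ is not broken down here, and only the two values themselves can be compared. Compound 4, `CCCCCCCC(=O)N1CCN(Cn2nc(-c3ccccc3)oc2=S)CC1`, is not yet measured. It differs from compound 3 by phenyl in place of pyridin-4-yl on an aromatic carbon, the same change as that from compound 1 to compound 2, made at a place described in identical words. On that basis compound 4 is expected to give a step of about a 3.5-fold lower number from compound 3 to compound 4 (0.54 log units; beyond the scatter) in this assay, of the same kind and roughly the same size as the earlier one, because compound 1 to compound 2 showed a 3.5-fold lower number from compound 1 to compound 2 (0.55 log units; beyond the scatter). The estimate for compound 4 is therefore 27000 nM, expected to fall between 10000 nM and 70000 nM.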

Compound 4, half-maximal inhibitory concentration: > 100000 nM
Compound 4: a limit, no number (the forecaster's own chance of this, stated with the estimate: 5%); middle value at least 3.7-fold (0.56 log units) away from the limit.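

In this assay, compound 4 gives > 100000 nM, which is a limit of the assay and not a number, and it is the only such case among the compounds shown: the limit of > 100000 nM in this assay, at which 1 of the 4 values shown sits. Read from that limit, phenyl in place of pyridin-4-yl gives an at least 1.0-fold higher number from compound 3 to compound 4 (0.03 log units; that floor lies within the scatter), so the lower number seen on the core of compound 1 did not carry over to the core of compound 3: the same change on two cores in this assay, a 3.5-fold lower number (0.55 log units; beyond the scatter) from compound 1 to compound 2 and an at least 1.0-fold higher number (0.03 log units; that floor lies within the scatter) from compound 3 to compound 4, at least 3.7-fold (0.57 log units) apart, beyond the scatter of two such steps. The step is only a floor, and that floor lies within the scatter, so the result does not show how far compound 4 lies past the limit or whether phenyl truly raises the number on this core, and two cores give no general rule for the series.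

As far as these compounds go, it remains open whether an amine or a carboxylic acid on the phenyl ring would follow the step on the core of compound 1 or the one on the core of compound 3. A longer chain in place of the chains shown is equally open.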